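This account rests on a few compounds, and the source may have more. Where it says the series, first, only, none or still open, it means among the compounds named here.

In an assay on HEK293 cells for positive allosteric modulation of metabotropic glutamate receptor 2 (Rattus norvegicus), read by thallium flux, with a stated time of 2.5 min (on this read-out lower numbers stand for an effect already at smaller amounts and higher numbers for an effect only at larger amounts of compound), compound 2 `Cc1c(OCCCCOc2ccc(C(=O)O)cc2)ccc(C(=O)CC(C)C)c1O` gives 122 nM, the lowest of the three numbers shown; compound 3 `CC(=O)c1ccc(OCCCCOc2cccc(C(=O)O)c2C)c(C)c1O` gives 200 nM, within the scatter of compound 2, while compound 1 `Cc1c(OCCCCOc2ccc(C(=O)O)cc2)ccc(C(=O)CC2CCCC2)c1O` gives 824 nM. Among the measured compounds shown here, the one single-point step measured so far is a 6.8-fold lower number from compound 1 to compound 2 (0.83 log units; beyond the scatter), and it concerns the group on the saturated chain carbon bound to the carbonyl carbon, not the part of the molecule changed here. Compound 4 `Cc1c(OCCCCOc2ccc(F)c(C(=O)O)c2)ccc(C(=O)CC(C)C)c1O` differs from compound 2 by 3-carboxy-4-fluorophenyl in place of 4-carboxyphenyl on an oxygen on a saturated carbon. For the measured compounds named here, no measured step touches this part of the structure, so the present data give no direction. The expected step in this assay is therefore within the scatter, a 1.2-fold higher number from compound 2 to compound 4 (0.09 log units; within the scatter). Compound 4 is estimated at 150 nM, with a range from 60 nM to 400 nM.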

Compound 4, half-maximal effective concentration: 153 nM
Estimate against measurement, compound 4: 1.0-fold (0.01 log units) below, within the range that was stated.
By their numbers in this assay, from the lowest: compounds 2, 4 and 3 (each within the scatter of the next); then compound 1.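

Among the compounds shown here, replacing 4-carboxyphenyl with 3-carboxy-4-fluorophenyl on an oxygen on a saturated carbon gives the first reading at this position: in this assay, a 1.3-fold higher number from compound 2 to compound 4 (0.10 log units; within the scatter), so the two groups cannot be told apart here. This single step combines a shifted carboxy group with an added fluorine, and the contribution of each remains unresolved. No evidence bears on this result. Still open, on these data alone, is whether 3-carboxyphenyl without fluorine would read the same, and whether a tetrazole or an amide could replace the carboxylic acid.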